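Chain Lengthening in an Acyltransferase Inhibitor Series

The source may report more compounds than this note shows. Statements on the series, on what has been measured and on what is new or still open speak of the compounds shown alone.

Measured compounds:
Compound 1: `CCCCCCCC/C=C/CCCCCCCC(=O)Nc1c(C)cccc1OCC`, 15 nM
Compound 2: `CCCCCCCC(C)(C)C(=O)Nc1c(OC)cc(OC)cc1OC`, 180 nM
Compound 3: `CCCCCCCCCCCCC1(C(=O)Nc2c(OC)cc(OC)cc2OC)CC1`, 58 nM

These values come from an assay on microsomes from intestine for inhibition of acyl-CoA:cholesterol acyltransferase (Oryctolagus cuniculus); on this read-out lower numbers stand for stronger inhibition and higher numbers for weaker inhibition. Compound 2 gives the highest number of the three, and its gaps to compound 3 and to compound 1 both lie beyond the scatter. Compound 4, `CCCCCCCCCCCCCCCCC(C)(C)C(=O)Nc1c(OC)cc(OC)cc1OC`, differs from compound 2 by nonyl in place of hydrogen on a saturated chain carbon, eight bonds along the chain from a carbonyl carbon. For the measured compounds named here, no measured pair shows this step directly, and compound 3 carries a different group at the chain carbon, so its value is only a general pointer. Compound 4 is nonetheless expected to reach a lower number, with the step of a 3.6-fold lower number from compound 2 to compound 4 (0.56 log units; beyond the scatter) beyond the scatter. For compound 4 the estimated value is 50 nM, with a range from 15 nM to 180 nM.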

Compound 4, half-maximal inhibitory concentration: 87 nM
Estimate against measurement, compound 4: 1.7-fold (0.24 log units) below; the range from low to high includes it.
By their numbers in this assay, from the lowest: compound 1; then compounds 3 and 4 (each within the scatter of the next); then compound 2.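

In this assay the series now shows a 2.1-fold lower number from compound 2 to compound 4 (0.32 log units; beyond the scatter) when nonyl replaces hydrogen on a saturated chain carbon, eight bonds along the chain from a carbonyl carbon. For the compounds shown here, this is the first pair differing in one place, so the earlier compounds could not show that this lengthening lowers the number, and only modestly. Nothing available explains the size of this step.

On these data alone, whether butyl, a longer chain or a carboxylic acid in place of nonyl would lower the number further remains open.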